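The source may report more compounds than this note shows. Statements on the series, on what has been measured and on what is new or still open speak of the compounds shown alone.

The three measured compounds:
Compound 1 `N#Cc1ccc(NC(=O)c2ccc(F)cc2O)cc1` gives 1380 nM in a functional assay on HL-60 cells (Homo sapiens) for cytotoxicity, read by luminescence and CellTiter-Glo, with a stated time of 3 days; on this read-out higher numbers stand for weaker inhibition and lower numbers for stronger inhibition.
Compound 2 `O=C(Nc1ccc(Br)c(Cl)c1)c1cc(F)ccc1O` gives 600 nM in this assay.
Compound 3 `O=C(Nc1cc(C(F)(F)F)cc(C(F)(F)F)c1)c1ccc(-c2ccccc2)cc1O` gives 1140 nM in this assay.

Among these three numbers, compound 2 has the lowest. Its gap to compound 3 lies within the usual scatter of repeated measurements, so compound 2 and compound 3 cannot be ranked against each other. Its gap to compound 1 lies beyond the scatter, so compound 2 inhibits more strongly than compound 1.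

Compound 4 `O=C(Nc1ccc(Cl)c(Cl)c1)c1cc(F)ccc1O` is the next compound to be measured. Compared with compound 2, the change is chloro in place of bromo on an aromatic carbon. Going by the values given here, no measured pair here differs in just one place, so the data give no direct step to lean on. A swap of one halogen for another of the same kind is the smallest sort of change in this set, so the step from compound 2 to compound 4 in this assay is expected to stay within the scatter, with no clear direction. On that basis compound 4 is estimated at 700 nM, with a range from 300 nM to 1800 nM. This estimate means an expected step of a 1.2-fold higher number from compound 2 to compound 4 (0.07 log units; within the scatter).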

Compound 4, half-maximal inhibitory concentration: 660 nM
Compound 4: middle estimate off by 1.1-fold (0.03 log units), on the high side; the measured number falls inside the stated range.
By their numbers in this assay, from the lowest: compounds 2, 4, 3 and 1 (each within the scatter of the next, the first and the last beyond it).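

In this assay, going by these compounds alone, the change of bromo to chloro gives a 1.1-fold higher number from compound 2 to compound 4 (0.04 log units; within the scatter), and this is the first comparison in the set in which only one place differs. It shows that on this aromatic carbon, ortho to a chloro group and para to a large group, the two halogens cannot be told apart in this read-out. So at this position, exchanging one of these halogens for the other leaves the number within the usual scatter, which the earlier compounds could not show, and nothing measured here offers an explanation for this result.

Two halogens alone do not show whether a halogen is needed on this carbon at all. A plain hydrogen, a methyl group, a methoxy group or an amine at the same place would test how much this position tolerates beyond chloro and bromo.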